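This account rests on a few compounds, and the source may have more. Where it says the series, first, only, none or still open, it means among the compounds named here.

Compound 1 `CCO/C(O)=C1\C(COCC(C)(C)O)=NC(C)=C(C(=O)OC)C1c1cccc(Cl)c1Cl`: 6.31 nM in a functional assay (aorta) with Rattus norvegicus as the target; on this read-out higher numbers stand for weaker inhibition and lower numbers for stronger inhibition
Compound 2 `CCO/C(O)=C1\C(COCC(C)(O)CNc2ncccn2)=NC(C)=C(C(=O)OC)C1c1cccc(Cl)c1Cl`: 39.8 nM

Compound 1 stands lowest of the two numbers measured in this assay; the nearest is compound 2, reached by a 6.3-fold higher number from compound 1 to compound 2 (0.80 log units; beyond the scatter). Compound 3 `CCO/C(O)=C1\C(COCC(C)(O)Cn2ccnc2)=NC(C)=C(C(=O)OC)C1c1cccc(Cl)c1Cl` differs from compound 1 by 1H-imidazol-1-yl in place of hydrogen on a saturated chain carbon, two bonds along the chain from an oxygen on a saturated carbon. Within the data shown here, the only step that bears on this is the one from compound 1 to compound 2, which added a ring-bearing group at the same place and moved the number beyond the scatter. A step of similar direction, perhaps somewhat smaller, is therefore expected: a 3.2-fold higher number from compound 1 to compound 3 (0.50 log units; beyond the scatter). Compound 3 is estimated at 20 nM, within 8 nM to 60 nM.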

Compound 3, half-maximal inhibitory concentration: 39.8 nM
Compound 3: the middle estimate sits 2.0-fold (0.30 log units) below what was measured; the measured number falls inside the stated range.
By their numbers in this assay, from the lowest: compound 1; then compounds 2 and 3 (each within the scatter of the next).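

In this assay, 1H-imidazol-1-yl on this saturated chain carbon gives a 6.3-fold higher number from compound 1 to compound 3 (0.80 log units; beyond the scatter), so a second ring-bearing group also lands beyond the scatter from the hydrogen of compound 1. Exchanging one ring-bearing group for the other gives no change at the digits printed from compound 2 to compound 3 (within the scatter), so (pyrimidin-2-yl)amino and 1H-imidazol-1-yl cannot be told apart at this position. Nothing available explains why these two different groups give the same number. From the compounds shown here alone, it remains open whether a group without a ring, such as a simple amine or a carboxylic acid, would give a similar number here. Going by these compounds, it is also open how a longer chain carrying the 1H-imidazol-1-yl ring would read.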